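A few compounds are considered here, and "the series" means these few. Any claim that something is new, unique, unknown or untested is made for them only; others in the source may bear on it.

Of the compounds shown here, three with a shared core have been measured in a physicochemical assay for solubility, read by HPLC, in phosphate buffer, measured as kinetic solubility, at pH 7.4; a higher number here means a more soluble compound, a lower number a less soluble compound. Compound 1, `CCC(=O)c1cc(-c2cccc(Cl)c2)n(-c2ccc(S(N)(=O)=O)cc2)c1C`, gives 12600 nM. Compound 2, `CCOC(=O)c1cc(-c2ccc(Cl)cc2)n(-c2ccc(S(N)(=O)=O)cc2)n1`, gives 53300 nM. Compound 3, `CCCC(=O)c1cc(-c2ccc(S(N)(=O)=O)cc2)n(-c2ccc(Cl)cc2)n1`, gives 25800 nM, which places it second highest of the three: compound 1 lies a step below it that goes beyond the scatter, and compound 2 lies a step above it that also goes beyond the scatter.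

Compound 4, `CN(C(=O)c1cc(-c2ccc(S(N)(=O)=O)cc2)n(-c2ccc(Cl)cc2)n1)C1CC1`, has not yet been measured. It differs from compound 3 in one place: cyclopropyl(methyl)amino in place of propyl on a carbonyl carbon. Seen one bond further out, the propylcarbonyl group of compound 3 becomes a cyclopropyl(methyl)carbamoyl group in compound 4, on a carbonyl carbon whose other neighbour is an aromatic carbon.

For the measured compounds named here, no two measured compounds here differ in only one place, so no measured step can be taken as a guide. Of compound 2 and compound 3 one can say only what their values show, a gap beyond the scatter between molecules built differently in more than one respect. The change from compound 3 to compound 4 is expected to shift the number only a little, toward higher solubility if at all, by a 1.6-fold higher number from compound 3 to compound 4 (0.19 log units; within the scatter). For compound 4 the estimated solubility in this assay is 40000 nM, with a range from 18000 nM to 90000 nM.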

Compound 4, solubility: 99600 nM
The estimate for compound 4 lay 2.5-fold (0.40 log units) below the measured number; measured number outside the range, above it.
By their numbers in this assay, from the lowest: compound 1; then compound 3; then compounds 2 and 4 (each within the scatter of the next).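

In this assay, for the compounds shown here, the exchange of propyl for cyclopropyl(methyl)amino on a carbonyl carbon gives a 3.9-fold higher number from compound 3 to compound 4 (0.59 log units; beyond the scatter) and is the only measured step here that changes a single place. It shows that what sits on this carbonyl carbon, whose other neighbour is an aromatic carbon, can move the number beyond the scatter while the rest of the molecule stays the same, something compounds 1, 2 and 3 could not show, since they differ in more than one respect. Nothing at hand explains why the number rises with this change.

The entering group brings a nitrogen, a methyl and a cyclopropyl ring together, so a single step cannot tell which of these parts carries the rise, and a dimethylamino, a cyclopropylamino or a morpholine group on the same carbonyl carbon would begin to separate them. Going by these compounds, it also remains open whether the same exchange would give a similar step on the differently built core of compound 1, which carries a propylcarbonyl-type ketone of its own.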